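A few compounds are considered here, and "the series" means these few. Any claim that something is new, unique, unknown or untested is made for them only; others in the source may bear on it.

The measured compounds:
Compound 1, `C[C@@H](Oc1cc2onc(CCC(=O)O)c2cc1Cl)c1ccc(Cl)cn1`: in a physicochemical assay for solubility, with a stated time of 24 h (on this read-out higher numbers stand for higher solubility and lower numbers for lower solubility), compound 1 gives > 620 ug/mL, which is a limit of the assay and not a number.
Compound 2, `CCOc1cc2oc(=O)n(CCC(=O)O)c2cc1Cl`: in this assay compound 2 gives > 1880 ug/mL, again a limit.
Compound 3, `O=C(O)CCn1c(=O)oc2cc(OCC3CC3)c(Cl)cc21`: in this assay compound 3 gives > 2060 ug/mL, also a limit.

Compound 1 thus stands at the limit of > 620 ug/mL in this assay, at which 1 of the 3 values shown sits, and where it truly lies past that point is not known. The same holds for the other two compounds, which sit at the limit of > 1880 ug/mL in this assay, at which 1 of the 3 values shown sits, and (the limit of > 2060 ug/mL in this assay, at which 1 of the 3 values shown sits). Going by the values given here, the single step between measured compounds, a step that the two limits leave unreadable from compound 2 to compound 3, concerns another part of the structure and gives no readable size.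

The compound not yet measured, compound 4, `C[C@@H](Oc1cc2onc(CCC(=O)O)c2cc1Cl)c1ccccn1`, differs from compound 1 by hydrogen in place of chloro on an aromatic carbon. Among the compounds with values here, no measured step covers this change, so the expectation rests on compound 1 alone. Compound 4 is expected to be soluble in this assay, with an estimate of 900 ug/mL and a range from 400 ug/mL to 2500 ug/mL. The expected step is a step that the limit leaves unreadable from compound 1 to compound 4, which is not expected to exceed the scatter.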

Compound 4, solubility: > 7440 ug/mL
Compound 4: no number, only a limit; the forecaster's own chance of this, stated with the estimate: 60%; middle value at least 8.2-fold (0.91 log units) from the limit.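

Compound 1 and compound 4 both stand only as limits in this assay, so no step can be read for hydrogen in place of chloro. The compounds shown leave open how far past its limit each truly lies, and whether this change shifts the read-out at all.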